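The compounds below may be only part of what the source reports. "The series", "measured", "known", "first", "only" and "open" are said of these compounds alone.

In a functional assay on HL-60 cells (Homo sapiens) for cytotoxicity, with a stated time of 24 h (on this read-out higher numbers stand for lower toxicity in this test and lower numbers for higher toxicity in this test), compound 1 (`COc1ccc(/C=C2\CCC/C(=C\c3ccccc3[N+](=O)[O-])C2=O)cc1`) gives 26000 nM and compound 2 (`O=C1/C(=C/c2ccc(F)cc2)CCC/C1=C\c1cccc([N+](=O)[O-])c1`) gives 1000 nM as its reading. Compound 2 therefore holds the lower of the two numbers, which marks it as the more toxic of the pair in this test, and the gap between them lies beyond the scatter. Compound 3 (`COc1ccc(/C=C2\CCC/C(=C\c3cccc([N+](=O)[O-])c3)C2=O)cc1`) differs from compound 2 in one place. The change methoxy in place of fluoro on an aromatic carbon puts methoxy in place of fluoro on an aromatic carbon, para to a large group. Going by the values given here, no measured pair isolates this swap, so any forecast remains loose. Compound 1 also carries methoxy and reads 26000 nM as its value, which tilts the expectation toward a higher number. The expected move a 2.5-fold higher number from compound 2 to compound 3 (0.40 log units; beyond the scatter) is a small rise that may not clear the scatter. For compound 3 the estimated value is 2500 nM with an expected range from 700 nM to 10000 nM in this test.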

Compound 3, half-maximal cytotoxic concentration: 7200 nM
Compound 3: the middle estimate sits 2.9-fold (0.46 log units) below what was measured; low and high end bracket the measured number.
By their numbers in this assay, from the lowest: compound 2; then compound 3; then compound 1.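

In this assay the change from 4-fluorophenyl to 4-methoxyphenyl gives a 7.2-fold higher number from compound 2 to compound 3 (0.86 log units; beyond the scatter) and this step lies beyond the scatter, so the group at this position of the ring can shift the reading. This is the one pair shown that isolates the change: with the rest of the molecule held the same, methoxy in place of fluoro goes with a higher number, which here means lower toxicity in this test. No accompanying data bear on why the number moves.

A single pair cannot show how other groups at this position would read, such as an amine, a hydroxyl or a longer chain like butoxy. It also leaves open whether the same swap would shift the number in the same direction elsewhere on the shared core.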